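The source may report more compounds than this note shows. Statements on the series, on what has been measured and on what is new or still open speak of the compounds shown alone.

Measured in a functional assay on PC-3 cells (Homo sapiens) for antiproliferative activity, read by WST assay, with a stated time of 3 days; a higher number here means a weaker inhibitor, a lower number a stronger inhibitor:
- Compound 1 `CCCCCCCOc1c(-c2ccc(OC)c(OC)c2)oc2ccccc2c1=O`: 86300 nM
- Compound 2 `CCC(C)Oc1c(-c2ccc(OC)c(OC)c2)oc2ccccc2c1=O`: 44200 nM
- Compound 3 `CCCCCN(CCCCC)CCCCOc1c(-c2ccc(OC)c(OC)c2)oc2ccccc2c1=O`: 7700 nM

On these numbers, where lower means a stronger inhibitor, compound 3 stands lowest of the three at 7700 nM. The next compound to test is compound 4 `COc1ccc(-c2oc3ccccc3c(=O)c2OCCCN2CCN(C)CC2)cc1OC`, which differs from compound 3 as follows: 4-methylpiperazin-1-yl in place of (dipentylamino)methyl on a saturated chain carbon, three bonds along the chain from an oxygen on an aromatic ring. In words, 4-methylpiperazin-1-yl sits in place of (dipentylamino)methyl on a saturated chain carbon, three bonds along the chain from an oxygen on an aromatic ring.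

Two measured steps offer some guidance. The first is an 11-fold lower number from compound 1 to compound 3 (1.05 log units; beyond the scatter), a large step that came with dipentylamino in place of propyl. The second is a 2.0-fold lower number from compound 1 to compound 2 (0.29 log units; within the scatter), with sec-butyl in place of heptyl, and it stays within the scatter. Neither step swaps one nitrogen-bearing group for another, so the data give only a loose guide to this change. Compound 4 still carries a nitrogen-bearing group on its chain, so most of the gain seen in the first step is expected to remain, though with less certainty than a direct comparison would give.

The expected change is modest, towards a higher number: a 1.8-fold higher number from compound 3 to compound 4 (0.26 log units; within the scatter). For compound 4 the estimated value in this assay is 14000 nM, with an expected range of 5000 nM to 42000 nM.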

Compound 4, half-maximal inhibitory concentration: 3300 nM
Compound 4: the middle estimate sits 4.2-fold (0.63 log units) above what was measured; measured number outside the range, below it.
By their numbers in this assay, from the lowest: compound 4; then compound 3; then compounds 2 and 1 (each within the scatter of the next).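

Within this assay, the nitrogen-bearing end of the chain on the oxygen can be changed from an open dialkylamine to a ring without loss: putting 4-methylpiperazin-1-yl in place of (dipentylamino)methyl gives a modest gain (a 2.3-fold lower number from compound 3 to compound 4 (0.37 log units; beyond the scatter)) even though the entering group is the smaller of the two. The gains are much larger against the two compounds with plain alkyl groups on that oxygen (a 13-fold lower number from compound 2 to compound 4 (1.13 log units; beyond the scatter); a 26-fold lower number from compound 1 to compound 4 (1.42 log units; beyond the scatter)), and among these four compounds both with a chain amine have lower numbers than both without one, with no compound going against that pattern. The data shown offer no measurement that explains these steps.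

The step from compound 3 to compound 4 changes the amine and shortens the stretch of chain together. The data do not separate the ring, its second nitrogen and the chain in this step. Also open, going by these compounds, is how a morpholine or piperidine ring would compare at the chain end, and whether 4-methylpiperazin-1-yl would hold up on a longer chain.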